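The compounds below may be only part of what the source reports. "The series", "measured", "known", "first", "only" and "open" are said of these compounds alone.

Measured so far in a functional assay on MDA-MB-435 cells (Homo sapiens) for antiproliferative activity; a higher number here means a weaker inhibitor of growth, a lower number a stronger inhibitor of growth
- compound 1 `Cc1cccc(-c2cc(O)c3ccc(C)nc3n2)c1` gives 32.4 nM
- compound 2 `Oc1cc(-c2ccc3ccccc3c2)nc2ncccc12` gives 1780 nM
- compound 3 `Cc1ccnc2nc(-c3ccc4ccccc4c3)cc(O)c12` gives 204 nM

Compound 2 has the highest number of the three, so it is the weakest growth inhibitor here, and both other compounds lie beyond the scatter from it. Compound 4 `Cc1ccc2c(O)cc(-c3ccc4ccccc4c3)nc2n1` is not yet measured. It derives from compound 2 by methyl in place of hydrogen on an aromatic carbon.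

Among the compounds with values here, the closest precedent is the same kind of replacement at another place on the shared core, an 8.7-fold lower number from compound 2 to compound 3 (0.94 log units; beyond the scatter) (modest, but beyond the scatter). Compound 1 (32.4 nM) carries its methyl at the place where compound 4 gains one, but it differs elsewhere, so its number gives only a loose hint and does not set the size of the step. A step of similar size and direction is therefore expected in this assay, estimated as a 9.9-fold lower number from compound 2 to compound 4 (1.00 log units; beyond the scatter) (toward stronger inhibition). Compound 4 is estimated at 180 nM (expected range 45 nM to 700 nM).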

Compound 4, concentration for 50% growth inhibition: 1580 nM
Estimate against measurement, compound 4: 8.8-fold (0.94 log units) below; measured number outside the range, above it.
By their numbers in this assay, from the lowest: compound 1; then compound 3; then compounds 4 and 2 (each within the scatter of the next).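

In this assay the methyl on the aromatic carbon next to the ring nitrogen gives a 1.1-fold lower number from compound 2 to compound 4 (0.05 log units; within the scatter) and so brings no change that can be read at this place. The same replacement elsewhere on the shared core gives an 8.7-fold lower number from compound 2 to compound 3 (0.94 log units; beyond the scatter) and lies beyond the scatter, so the effect of this methyl on the series depends on where it sits, at least for these two places. No measurement at hand accounts for the contrast between the two places.

Going by these compounds, whether an ethyl, a methoxy or an amine at this same place would also stay within the scatter of compound 2 remains open. The compounds shown also leave open what this methyl contributes on the core of compound 1, which has no partner lacking it here.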